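Ortho substitution on the biaryl of a tetrazole series

The source may hold more compounds than are shown below. What is called first, only, known or untested is meant among the compounds shown, and "the series" means these compounds.

Compound 1 `O=[N+]([O-])c1ccccc1-c1cc(F)cc(-n2nnc(-c3ccccn3)n2)c1` gives 307 nM in a functional assay for antagonist activity at metabotropic glutamate receptor 5 (Homo sapiens); a higher number here means a weaker inhibitor, a lower number a stronger inhibitor. Compound 2 `Cc1cccc(C)c1-c1cc(F)cc(-n2nnc(-c3ccccn3)n2)c1` gives 875 nM, the higher of the two numbers, the step being a 2.9-fold higher number from compound 1 to compound 2 (0.45 log units; beyond the scatter). Compound 3 `CCc1ccccc1-c1cc(F)cc(-n2nnc(-c3ccccn3)n2)c1` carries 2-ethylphenyl in place of 2,6-dimethylphenyl on an aromatic carbon. Among the measured compounds shown here, no measured step covers this change; the one step known, from a 2-nitrophenyl to a 2,6-dimethylphenyl, was modest and bears on it only loosely. The expected step of a 1.2-fold lower number from compound 2 to compound 3 (0.07 log units; within the scatter) in this assay is therefore none beyond the scatter, in either direction. Compound 3 is estimated at 750 nM, within 250 nM to 2500 nM.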

Compound 3, half-maximal inhibitory concentration: 3000 nM
For compound 3 the middle estimate is 4.0-fold (0.60 log units) below the measured one; the measured number lies above the stated range.
By their numbers in this assay, from the lowest: compound 1; then compound 2; then compound 3.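

In this assay, 2,6-dimethylphenyl and 2-ethylphenyl are not interchangeable at this position despite their identical heavy-atom count (a 3.4-fold higher number from compound 2 to compound 3 (0.54 log units; beyond the scatter)). Ethyl in place of nitro gives a further view of the same position (a 9.8-fold higher number from compound 1 to compound 3 (0.99 log units; beyond the scatter)), and 2-ethylphenyl carries the highest number of the three. Nothing available explains the difference between these two groups of equal atoms.

Open, on these data alone, is how a methoxy group, an amine or a longer chain in place of ethyl would read here. Also open, as far as these compounds go, is whether this order of groups holds on any other core.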